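Shortening the phenoxyalkyl linker of a phthalimide-type amide

A few compounds are considered here, and "the series" means these few. Any claim that something is new, unique, unknown or untested is made for them only; others in the source may bear on it.

Two analogues built on a shared core have been examined in an assay on isolated protein for inhibition of metabotropic glutamate receptor 5 (Homo sapiens), tested at 10 uM; a higher number here means more inhibition at the concentration tested (going by the name of the read-out), a lower number less inhibition. Compound 1 `Cc1ccc(CNC(=O)c2ccc(N3C(=O)C4CC=CCC4C3=O)cc2)cc1C` returns only a limit in this assay, < 35%. Compound 2 `Cc1ccc(OCCCNC(=O)c2ccc(N3C(=O)C4CC=CCC4C3=O)cc2)cc1C` likewise returns only a limit, < 35%. Compound 2 therefore stands at the floor of what this assay reports, as seen in the limit of < 35% in this assay, at which 2 of the 2 values shown sit.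

Compound 3 `Cc1ccc(OCCNC(=O)c2ccc(N3C(=O)C4CC=CCC4C3=O)cc2)cc1C` is the next compound to be measured. It differs from compound 2 in one place only: 3,4-dimethylphenoxy in place of (3,4-dimethylphenoxy)methyl on a saturated chain carbon, two bonds along the chain from an amide-type nitrogen. Within the data shown here, no step between measured compounds exists for comparison, and both measured compounds sit at the limit, so the expected step that the limit leaves unreadable from compound 2 to compound 3 in this assay is none beyond the scatter. Compound 3 is accordingly estimated to give 20% in this assay, within a range of 0% to 40%, and is most likely to be reported again only as a limit.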

Compound 3, a percentage reported as inhibition, at one concentration (the size of the read-out at that concentration, not a potency): < 35%
Compound 3 was reported as a limit; the forecaster's own chance of this, stated with the estimate: 75%; the middle value does not contradict the limit.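

Among these compounds, compound 1, compound 2 and compound 3 are all reported only as a limit, so no step among them can be read in this assay: the limit of < 35% in this assay, at which 3 of the 3 values shown sit. On these data alone, whether changing the linker between the 3,4-dimethylphenyl ring and the amide alters inhibition at all remains open.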